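The source may report more compounds than this note shows. Statements on the series, on what has been measured and on what is new or still open speak of the compounds shown alone.

Compound 2 `CC(C)c1c(C(=O)N(C)Cc2cccc(F)c2)nn(-c2ccc(F)cc2)c1OC[C@@H](O)C[C@@H](O)CC(=O)O` gives 14 nM in an assay on microsomes from liver for inhibition of 3-hydroxy-3-methylglutaryl-coenzyme A reductase (Rattus norvegicus) (a higher number here means a weaker inhibitor, a lower number a stronger inhibitor), and compound 1 `COc1ccccc1CNC(=O)c1nn(-c2ccc(F)cc2)c(OC[C@@H](O)C[C@@H](O)CC(=O)O)c1C(C)C` gives 22 nM, so the two stand within the scatter of each other; the step of a 1.6-fold lower number from compound 1 to compound 2 (0.20 log units; within the scatter) changes the group on the carbonyl carbon. Compound 3 `Cc1cccc(CN(C)C(=O)c2nn(-c3ccc(F)cc3)c(OC[C@@H](O)C[C@@H](O)CC(=O)O)c2C(C)C)c1` keeps that group and differs from compound 2 only by methyl in place of fluoro on an aromatic carbon. Within the data shown here, no measured step exchanges fluoro for methyl on that ring, and the one step recorded is itself within the scatter, so nothing points to a shift beyond the scatter in this assay. Compound 3 is therefore expected near 14 nM, between 6 nM and 35 nM, a step of no change at the digits printed from compound 2 to compound 3 (within the scatter).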

Compound 3, half-maximal inhibitory concentration: 37 nM
Compound 3: the middle estimate sits 2.6-fold (0.42 log units) below what was measured; the measured number lies above the stated range.
By their numbers in this assay, from the lowest: compounds 2, 1 and 3 (each within the scatter of the next, the first and the last beyond it).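

Methyl in place of fluoro on this aromatic carbon gives the only step in this assay that passes beyond the scatter (a 2.6-fold higher number from compound 2 to compound 3 (0.42 log units; beyond the scatter)), so this position is not indifferent to the group it carries. The wider exchange on the carbonyl carbon stays within the scatter (a 1.7-fold higher number from compound 1 to compound 3 (0.23 log units; within the scatter)). No measurement available here explains the step.

Going by these compounds, whether chloro or methoxy on this carbon would read closer to fluoro or to methyl remains open. So does whether the same exchange would give a similar step with the amide hydrogen in place of the N-methyl group.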